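The compounds below may be only part of what the source reports. "The series", "measured", "known", "first", "only" and "open" are said of these compounds alone.

Of the compounds shown here, three have so far been tested in an assay on nucleic acid for inhibition of Nucleic Acid, read by fluorescence, tested at 100 uM; a higher number here means more inhibition at the concentration tested (going by the name of the read-out), a lower number less inhibition. Compound 1 `CC(C)CCN(C)Cc1cn(CC(O)COC(=O)NCc2ccccc2)nn1` gives 26%. Compound 2 `OC(COCc1ccccc1)Cn1cc(CN2CCN(c3ccccc3)CC2)nn1` gives 37%. Compound 3 `CCCCNC(=O)OCC(O)Cn1cc(CN(C)CC2CCCCC2)nn1` gives 12%. Among these three, compound 2 stands highest: compound 1 lies well below it, by a gap beyond the usual scatter, and compound 3 lies further below still, also beyond the scatter. Compound 2 therefore shows the highest inhibition of the three in this assay at the concentration tested.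

The next compound, compound 4 `O=C(OCC(O)Cn1cc(CN2CCN(c3ccccc3)CC2)nn1)c1ccccc1`, keeps almost everything of compound 2 and changes a single group: benzoyl in place of benzyl on an oxygen on a saturated carbon. Within the data shown here, no pair of already measured compounds differs in just this way, so there is no measured step to lean on. With only the three values above to go by, the step from compound 2 to compound 4 is expected to be small, perhaps within the scatter, with no clear direction. Compound 4 is therefore estimated to give about 33% in this assay, most likely somewhere between 15% and 50%, meaning an expected step of a number 4 percentage points lower from compound 2 to compound 4 (within the scatter).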

Compound 4, a percentage reported as inhibition, at one concentration (the size of the read-out at that concentration, not a potency): 11%
Compound 4: middle estimate off by 22 percentage points, on the high side; the measured number lies below the stated range.
By their numbers in this assay, from the lowest: compounds 4 and 3 (each within the scatter of the next); then compound 1; then compound 2.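

In this assay, the group on this oxygen clearly matters: benzoyl in place of benzyl gives a number 26 percentage points lower from compound 2 to compound 4 (beyond the scatter), a drop beyond the usual scatter. Both groups carry the same six-membered aromatic ring of carbon only, so this large step comes with a small change in the counted atoms: one added carbonyl oxygen, which is also one added hydrogen-bond acceptor. Nothing measured here explains why the swap lowers the reading.

Among these compounds, with only this one pair, the carbonyl's own part in the drop cannot be separated from the rest of the change, and the step is known only for this one shared core. On these data alone, how a plain methyl or an acetyl on the same oxygen would read also stays open, as does whether a longer chain between the oxygen and the aromatic ring would shift the number.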